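This account rests on a few compounds, and the source may have more. Where it says the series, first, only, none or still open, it means among the compounds named here.

Measured compounds:
compound 1 `Nc1ccc(/C=C/c2cccc(O)c2)cc1` with 24.8 ug/mL
compound 2 `Nc1ccc(/C=C/c2ccc(O)cc2)cc1` with 2.2 ug/mL
compound 3 `COc1cccc(/C=C/c2ccc(N)cc2)c1` with 52 ug/mL

Three stilbene-type anilines were tested in a functional assay on MCF7 cells (Homo sapiens) for inhibition, read by MTT assay, with a stated time of 2 days; a higher number here means a weaker inhibitor, a lower number a stronger inhibitor. Compound 1 and compound 2 are built from the same atoms joined differently; the difference between the two cores is not broken down here. Compound 2 gives the lowest number of the three, and its steps to compound 1 and to compound 3 are both beyond the scatter, so among these it is the strongest inhibitor. Compound 3 is the methyl ether of compound 1, the change being (methyl in place of hydrogen on an oxygen on an aromatic ring), and this step, a 2.1-fold higher number from compound 1 to compound 3 (0.32 log units; beyond the scatter), is modest but beyond the scatter.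

Compound 4 `COc1ccc(/C=C/c2ccc(N)cc2)cc1` is the corresponding methyl ether of compound 2. Within the data shown here, its relation to compound 2 is methyl in place of hydrogen on an oxygen on an aromatic ring, the same change as the one from compound 1 to compound 3, at a place described in the same words. Among the measured compounds shown here, the account therefore expects the step from compound 2 to compound 4 to be of a size comparable to that already seen, a 2.3-fold higher number from compound 2 to compound 4 (0.36 log units; beyond the scatter) beside a 2.1-fold higher number from compound 1 to compound 3 (0.32 log units; beyond the scatter), because the only measured example of this change, a 2.1-fold higher number from compound 1 to compound 3 (0.32 log units; beyond the scatter), is modest; the range is kept wider because that example sits on a different core. For compound 4 in this assay the estimate is 5 ug/mL, between 2 ug/mL and 15 ug/mL.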

Compound 4, half-maximal inhibitory concentration: 0.0021 ug/mL
Compound 4: the middle estimate sits 2400-fold (3.38 log units) above what was measured, outside the stated range (below it).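

On the core of compound 2, methyl in place of hydrogen on an oxygen on an aromatic ring, read as hydroxy to methoxy, gives a 1000-fold lower number from compound 2 to compound 4 (3.02 log units; beyond the scatter) in this assay. Set beside the same change on the core of compound 1, the step differs in both direction and size, so the result from one core did not carry over to the other in this series: the same change on two cores in this assay, a 2.1-fold higher number (0.32 log units; beyond the scatter) from compound 1 to compound 3 and a 1000-fold lower number (3.02 log units; beyond the scatter) from compound 2 to compound 4, 2200-fold (3.34 log units) apart, beyond the scatter of two such steps These two pairs show that the outcome of this change depends on which of these two cores carries it, but they do not show which feature of the cores is responsible, nor do they give a rule for predicting the change on any further core.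

Among these compounds, it remains open whether an ethoxy group, a longer chain on that oxygen, or an amine or a carboxylic acid in place of the hydroxy group would follow the step seen with compound 4 or the one seen with compound 3. As far as these compounds go, it also remains open whether the contrast between the two cores would appear in cells other than those of this assay.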